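From vinylcarbonyl to (3-methoxyphenyl)carbonyl on the shared core

This account rests on a few compounds, and the source may have more. Where it says the series, first, only, none or still open, it means among the compounds named here.

Values in a functional assay on A-375 cells (Homo sapiens) for cytotoxicity, read by MTT assay (a higher number here means a weaker inhibitor, a lower number a stronger inhibitor), so far
- compound 1 `COc1ccc(/C=C/C(=O)c2ccc(OC)c3c2OC(C)(C)C=C3)cc1OCCCN(C)C` gives 4100 nM
- compound 2 `C=CC(=O)Oc1cc(/C=C/C(=O)c2ccc(OC)c3c2OC(C)(C)C=C3)ccc1OC` gives 390 nM
- compound 3 `COc1cccc(C(=O)Oc2cc(/C=C/C(=O)c3ccc(OC)c4c3OC(C)(C)C=C4)ccc2OC)c1` awaits measurement

Compound 2 holds the lower of the two numbers, and the gap to compound 1 lies beyond the scatter. The next compound changes only the group carried on its ester carbonyl. In compound 3, 3-methoxyphenyl stands in place of vinyl on a carbonyl carbon (3-methoxyphenyl in place of vinyl on a carbonyl carbon). For the measured compounds named here, one measured step bears on this, at the same oxygen, namely the large 11-fold lower number from compound 1 to compound 2 (1.02 log units; beyond the scatter) in this assay on swapping 3-(dimethylamino)propyl for vinylcarbonyl. Going by the values given here, that step shows the number can move widely with the group on this oxygen, but it does not involve the group now entering, and no measured compound carries an aromatic ring at this carbonyl. Among the compounds with values here, with compound 2 at 390 nM as the lowest number so far, a moderate move upward seems more likely than a further drop. The expected change is a 2.1-fold higher number from compound 2 to compound 3 (0.31 log units; beyond the scatter) in this estimate, though it remains uncertain. For compound 3 the estimated value is 800 nM with an expected range of 250 nM to 2800 nM in this assay for now.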

Compound 3, half-maximal inhibitory concentration: 800 nM
The estimate for compound 3 equals the measured number at the digits printed; the measured number falls inside the stated range.
By their numbers in this assay, from the lowest: compound 2; then compound 3; then compound 1.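

In this assay the group on this carbonyl carbon can grow from vinyl, with 2 heavy atoms, to 3-methoxyphenyl, with 8 heavy atoms and an aromatic ring, at a limited cost: the change gives a 2.1-fold higher number from compound 2 to compound 3 (0.31 log units; beyond the scatter) and is modest, though beyond the scatter. The lower number seen with vinylcarbonyl on this oxygen is therefore not unique to that group, since (3-methoxyphenyl)carbonyl in place of 3-(dimethylamino)propyl also gives a 5.1-fold lower number from compound 1 to compound 3 (0.71 log units; beyond the scatter) on the shared core, and neither of the two carbonyl-bearing compounds goes against this. Nothing available explains why the number moves with these groups.

The compounds shown leave open whether the aromatic ring or its methoxy group accounts for the rise, a question that a plain phenyl group on this carbonyl carbon would bear on. They also leave open how a saturated ethyl group in place of vinyl, or an amide nitrogen in place of the ester oxygen, would read in this assay at this position.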